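Pyrimidinyl amide built from an inactive series member

The source may report more compounds than this note shows. Statements on the series, on what has been measured and on what is new or still open speak of the compounds shown alone.

Measured so far in a functional assay on cells for agonist activity at D(4) dopamine receptor (Homo sapiens), read by TR-FRET and cAMP accumulation, with a stated time of 30 min; on this read-out lower numbers stand for an effect already at smaller amounts and higher numbers for an effect only at larger amounts of compound:
compound 1 `CCc1cccc(NC(=O)CN2CCN(c3ccccn3)CC2)c1`: 28.7 nM
compound 2 `Cc1ccc(C2CCN(CC(=O)Nc3cccc(C)c3)CC2)cc1`: "not active" (no number reported)
compound 3 `CCc1cccc(NC(=O)CN2CCN(c3ccc(Cl)cn3)CC2)c1`: "not active" (no number reported)

Compound 3 stands without a number in this assay; its entry reads "not active" (no number reported). Compound 2 likewise returns "not active" (no number reported). Among the compounds with values here, compound 1 is the only member with a value, giving 28.7 nM in this assay.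

Compound 4 `O=C(CN1CCN(c2ccc(Cl)cn2)CC1)Nc1cncnc1` has not yet been measured. It differs from compound 3 by pyrimidin-5-yl in place of 3-ethylphenyl on an amide-type nitrogen. Within the data shown here, no step between two measured compounds covers this change, so the numbers give no direction for it and no size to compare against; the step from compound 3 to compound 4 cannot be placed against the scatter. The starting point is a compound with no reported activity, so the expectation is set low rather than shifted in either direction.

Given that compound 3 shows "not active" (no number reported), the most likely outcome expected for compound 4 is again no number. If a value is obtained, compound 4 is estimated at 5000 nM, with an expected range from 500 nM to 50000 nM.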

Compound 4, half-maximal effective concentration: "not active" (no number reported)
Compound 4: no number reported; no gap can be computed for the estimate.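

In this assay compound 3 gives "not active" (no number reported) and compound 4 gives "not active" (no number reported) so no step can be read between them. Left open is what pyrimidin-5-yl in place of 3-ethylphenyl does on the core of compound 1 with its 28.7 nM in this series. No measured evidence bears on this result.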